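Swapping the prenyl group for a chlorobenzyl on the core

The compounds below may be only part of what the source reports. "The series", "measured", "known", "first", "only" and "open" are said of these compounds alone.

Measured so far:
compound 1 `CC(C)=CCn1c(CN2CCN(C(=O)C3CC3)CC2)nc2ccccc21`: 74.3%
compound 2 `Cc1cccc(Cn2c(CN3CCN(C(=O)c4ccc(Cl)cc4)CC3)nc3ccccc32)c1`: 23.2%

In an assay on isolated protein for inhibition of aldehyde dehydrogenase 1A1 (Homo sapiens), read by spectrophotometry, tested at 10 uM (on this read-out higher numbers stand for more inhibition at the one concentration tested (going by the name of the read-out) and lower numbers for less inhibition), compound 1 gives 74.3%, the highest of the two numbers shown. Compound 2 gives 23.2% in this assay, a gap beyond the usual scatter; compound 2 differs from compound 1 in more than one place, so its value shows only where a related compound stands, not the effect of any single change.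

Compound 3 `O=C(C1CC1)N1CCN(Cc2nc3ccccc3n2Cc2ccc(Cl)cc2)CC1` has not been measured in this assay. It differs from compound 1 in one place: 4-chlorophenyl in place of 2-methylprop-1-en-1-yl on a saturated chain carbon bound to an aromatic nitrogen. The 3-methylbut-2-en-1-yl of compound 1 becomes a 4-chlorobenzyl, while the cyclopropanecarbonyl on the other side of the shared core is kept.

Among the measured compounds shown here, no measured pair isolates this change. For the measured compounds named here, the only other compound, compound 2, carries an aromatic group at the same place and sits much lower, but it also bears a different amide. The author therefore expects a step of a number 24.3 percentage points lower from compound 1 to compound 3 (beyond the scatter) downward, likely beyond the scatter, and estimates that compound 3 gives 50% in this assay, within a range of 20% to 78%.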

Compound 3, a percentage reported as inhibition, at one concentration (the size of the read-out at that concentration, not a potency): 56.6%
Compound 3: middle estimate off by 6.6 percentage points, on the low side; the range from low to high includes it.
By their numbers in this assay, from the lowest: compound 2; then compound 3; then compound 1.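

Among the compounds shown here, with the cyclopropanecarbonyl held constant, this assay gives the first clean reading of this position: replacing 3-methylbut-2-en-1-yl with 4-chlorobenzyl on a saturated chain carbon bound to an aromatic nitrogen gives a step of a number 17.7 percentage points lower from compound 1 to compound 3 (beyond the scatter), so the prenyl group and the chlorobenzyl group are not interchangeable here. The change lowers inhibition without removing it, since compound 3 still gives 56.6% at the one concentration tested, which shows that a 4-chlorophenyl can be carried at this place with a modest step. No measurement shown explains why the step goes this way or has this size.

For the compounds shown here, the single step cannot separate the part played by the aromatic ring from that of its chlorine, and a plain benzyl or a 4-methoxybenzyl on the same cyclopropanecarbonyl compound would speak to that. Going by these compounds, it also remains open how a saturated chain such as 3-methylbutyl would compare with the 3-methylbut-2-en-1-yl of compound 1, and whether this step would hold with a different amide on the other side of the shared core.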